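Replacing methoxycarbonyl with hydroxy: working notes on compound 4

This account rests on a few compounds, and the source may have more. Where it says the series, first, only, none or still open, it means among the compounds named here.

In an ADME assay on HepG2 cells (Homo sapiens) for cytotoxicity, with a stated time of 72 h (a higher number here means that more compound is needed for the effect, a lower number that less compound is needed), compound 3 (`COC(=O)c1ccc(NC(=O)Nc2cc(C)nc3ccccc23)cc1`) gives 20000 nM and compound 1 (`CC(=O)c1ccc(NC(=O)Nc2cc(C)nc3ccccc23)cc1`) gives 19000 nM. Going by the values given here, these are the only two numeric values so far, and they lie within the scatter of each other. Compound 2 (`Cc1cc(NC(=O)Nc2ccccc2N)c2ccccc2n1`) is reported as > 25000 nM, which is a limit of the assay and not a number.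

Compound 4 (`Cc1cc(NC(=O)Nc2ccc(O)cc2)c2ccccc2n1`) carries hydroxy in place of methoxycarbonyl on an aromatic carbon, para to a large group: hydroxy in place of methoxycarbonyl on an aromatic carbon.

Among the compounds with values here, only one measured step is available as a guide: a 1.1-fold higher number from compound 1 to compound 3 (0.02 log units; within the scatter). That step exchanges methoxy for methyl on a carbonyl carbon and keeps the carbonyl, whereas the carbonyl leaves with the methoxycarbonyl in compound 4, so it bears on this change only loosely. With no measured step beyond the scatter, none is expected here in this assay. The expected size is no change at the digits printed from compound 3 to compound 4 (within the scatter).

For compound 4 the estimated value is 20000 nM, with an expected range of 9000 nM to 30000 nM.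

A result given only as a limit also remains possible, in view of the limit of > 25000 nM in this assay, at which 1 of the 3 values shown sits.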

Compound 4, half-maximal effective concentration: > 25000 nM
Compound 4: a limit, no number; the forecaster's own chance of this, stated with the estimate: 30%; at least 1.2-fold (0.09 log units) between middle value and limit.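

Placed on the aromatic carbon para to a large group, hydroxy in place of methoxycarbonyl gives an at least 1.2-fold higher number from compound 3 to compound 4 (0.09 log units; that floor lies within the scatter), and hydroxy in place of acetyl gives an at least 1.3-fold higher number from compound 1 to compound 4 (0.11 log units; that floor lies within the scatter). From the compounds shown here alone, both floors lie within the scatter, so this assay does not separate hydroxy from either carbonyl-bearing group, and the true size of each step remains unknown. Until now this position had carried only those two carbonyl-bearing groups, and compound 4 is the first compound with a group lacking a carbonyl there; its result is a limit and not a number, which adds a second such result to the set: the limit of > 25000 nM in this assay, at which 2 of the 4 values shown sit.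

Compound 2 and compound 4 are both limits, so the step between them cannot be read and says nothing about 4-hydroxyphenyl against 2-aminophenyl. Still open, going by these compounds, is whether a carboxylic acid or an amine at this same position would give a number or also reach the limit, and how far past the limit compound 4 lies.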